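This account rests on a few compounds, and the source may have more. Where it says the series, first, only, none or still open, it means among the compounds named here.

Four compounds sharing a fused two-ring core carrying a methoxy-bearing aromatic group were compared in an ADME assay on MDCK cells (Canis lupus familiaris) for cytotoxicity, read by MTT assay, with a stated time of 48 h; on this read-out higher numbers stand for lower toxicity in this test and lower numbers for higher toxicity in this test. Compound 1 `COc1ccc([C@H]2CC(C)(O)[C@@H]3CC[C@@H](C)C[C@H]3O2)cc1` gives 689000 nM. Compound 3 `COc1ccc([C@H]2CC(C)(F)[C@@H]3CC[C@@H](C)C[C@H]3O2)cc1` gives 171000 nM. The change between them is fluoro in place of hydroxy on a saturated ring carbon, and it produced a 4.0-fold lower number from compound 1 to compound 3 (0.61 log units; beyond the scatter). Compound 2 `COc1cccc([C@H]2CC(C)(O)[C@@H]3CC[C@@H](C)C[C@H]3O2)c1OC` carries two methoxy groups on its aromatic ring; how its core differs from the core of compound 1 is not broken down here. In this assay compound 2 reaches only a limit, not a number, namely > 937000 nM. This is the limit of > 937000 nM in this assay, at which 1 of the 3 values shown sits. Compound 4 `COc1cccc([C@H]2CC(C)(F)[C@@H]3CC[C@@H](C)C[C@H]3O2)c1OC` has not yet been measured in this assay. It differs from compound 2 by fluoro in place of hydroxy on a saturated ring carbon. Around the site of this change, compound 2 is described as having a large group two ring bonds away, where compound 1 has a group of 8 heavy atoms, so the change is the same kind of change rather than the same one. Since the value of compound 2 is only a limit, the starting point is uncertain. The step from compound 2 to compound 4 is expected to be an at least 3.1-fold lower number from compound 2 to compound 4 (0.49 log units; beyond the scatter). That expectation rests on compound 1 and compound 3, whose change gave a 4.0-fold lower number from compound 1 to compound 3 (0.61 log units; beyond the scatter). Compound 4 is therefore estimated at 300000 nM, between 120000 nM and 937000 nM.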

Compound 4, half-maximal cytotoxic concentration: 180000 nM
Compound 4: the middle estimate sits 1.7-fold (0.22 log units) above what was measured; the measured number falls inside the stated range.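

In this assay, fluoro in place of hydroxy on a saturated ring carbon gives an at least 5.2-fold lower number from compound 2 to compound 4 (0.71 log units; beyond the scatter), so the direction seen on the core of compound 1 appears again on the core of compound 2, which carries two methoxy groups. Set together, the two steps point the same way, but whether their sizes match remains unsettled: the same change on two cores in this assay, a 4.0-fold lower number (0.61 log units; beyond the scatter) from compound 1 to compound 3 and an at least 5.2-fold lower number (0.71 log units; beyond the scatter) from compound 2 to compound 4; the limit leaves it open whether they differ. Compound 2 has only a limit and not a number, so its step has no exact size, and two cores are too few to show that the change would carry over to any further core: the limit of > 937000 nM in this assay, at which 1 of the 4 values shown sits.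

The compounds shown leave open how an amine or a chlorine on that same saturated ring carbon would compare with hydroxy and fluoro. They also leave open whether the step would hold with a nitrile or a carboxylic acid on the aromatic ring in place of the methoxy groups.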